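Methoxy on compound 3: the limit is expected to hold

A few compounds are considered here, and "the series" means these few. Any claim that something is new, unique, unknown or untested is made for them only; others in the source may bear on it.

In an ADME assay on Raji cells (Homo sapiens) for cytotoxicity, with a stated time of 72 h (on this read-out lower numbers stand for an effect already at smaller amounts and higher numbers for an effect only at larger amounts of compound), compound 3 (`Cc1cc(NC(=O)Nc2cccc(F)c2)c2ccccc2n1`) reads > 25000 nM as a limit of the assay and not a number. Compound 2 (`Cc1ccc(NC(=O)Nc2cc(C)nc3ccccc23)cc1`) reads > 25000 nM in this assay and this is also a limit. Compound 1 (`COc1ccc(NC(=O)Nc2cc(C)nc3ccccc23)cc1OC`) reads > 25000 nM in this assay and this too is a limit. All three values shown sit at the same point (the limit of > 25000 nM in this assay, at which 3 of the 3 values shown sit), so compound 3 has no readable place within the set.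

Compound 4 (`COc1ccc(NC(=O)Nc2cc(C)nc3ccccc23)cc1F`) differs from compound 3 by methoxy in place of hydrogen on an aromatic carbon, ortho to a fluoro group and para to a large group (methoxy in place of hydrogen on an aromatic carbon). Among the compounds with values here, the only measured step between these compounds (a step that the two limits leave unreadable from compound 2 to compound 3) has no readable size. Compound 1 also carries methoxy and stays at a limit with > 25000 nM as its reading. The expected outcome in this assay is a step that the limit leaves unreadable from compound 3 to compound 4 with no direction foreseen beyond the scatter. Compound 4 is estimated at 30000 nM with an expected range of 12000 nM to 60000 nM and a reading at the limit is likely.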

Compound 4, half-maximal effective concentration: > 25000 nM
Compound 4 was reported as a limit; the forecaster's own chance of this, stated with the estimate: 85%; the middle value does not contradict the limit.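

No new step can be read, since compound 4 stays at a limit, as do compound 1 and compound 3, and all four compounds share one reading: the limit of > 25000 nM in this assay, at which 4 of the 4 values shown sit. The compounds shown leave open whether any change on the shared core gives a readable value, and how large any step would be.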